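Lengthening the amide chain from methyl to propyl

The source may report more compounds than this note shows. Statements on the series, on what has been measured and on what is new or still open speak of the compounds shown alone.

In a functional assay on the whole organism with Mus musculus as the target (on this read-out lower numbers stand for an effect already at smaller amounts and higher numbers for an effect only at larger amounts of compound), compound 1 (`NC(=O)Cn1c(-c2ccc(Cl)cc2)nc2cccnc21`) stands at 4.1 mg/kg while compound 2 (`CNC(=O)Cn1c(-c2ccc(Cl)cc2)nc2cccnc21`) stands at 12.5 mg/kg and so holds the higher of the two numbers. Compound 3 (`CCCNC(=O)Cn1c(-c2ccc(Cl)cc2)nc2cccnc21`) carries ethyl in place of hydrogen on a saturated chain carbon bound to an amide-type nitrogen, which turns methyl into propyl. Within the data shown here, one measured step bears on this change: methyl in place of hydrogen on an amide-type nitrogen (a 3.0-fold higher number from compound 1 to compound 2 (0.48 log units; beyond the scatter)), modest and beyond the scatter. It is thin evidence, since it sits on the nitrogen and not on the chain carbon. A further modest rise in this assay is still expected, though a result within the scatter remains possible. The estimated change is a 1.6-fold higher number from compound 2 to compound 3 (0.20 log units; within the scatter) in the same direction. For compound 3 the estimate is 20 mg/kg with 7 mg/kg to 55 mg/kg as the expected range.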

Compound 3, dose for half-maximal effect: 37.5 mg/kg
The estimate for compound 3 lay 1.9-fold (0.27 log units) below the measured number, within the range that was stated.
By their numbers in this assay, from the lowest: compound 1; then compound 2; then compound 3.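

In this assay, ethyl in place of hydrogen on a saturated chain carbon bound to an amide-type nitrogen gives a 3.0-fold higher number from compound 2 to compound 3 (0.48 log units; beyond the scatter), so the rise does not stop at methyl and this chain position also responds to substitution. Propyl in place of hydrogen on the amide-type nitrogen gives a 9.1-fold higher number from compound 1 to compound 3 (0.96 log units; beyond the scatter), and the numbers in this set of three rise with each longer chain, with no compound going against that order. No evidence is available on what lies behind this rise. From the compounds shown here alone, whether a longer chain such as butyl or pentyl continues the trend remains open. Equally open, going by these compounds, is how a branched isopropyl group, or a propyl chain ending in an amine or a carboxylic acid, would compare with the plain propyl chain.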